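Pyridinyl for Thiophenyl on a Shared Core

The source may hold more compounds than are shown below. What is called first, only, known or untested is meant among the compounds shown, and "the series" means these compounds.

Three compounds share one core: compound 1 `Oc1cccc(-c2cc(-c3ccsc3)cc(-c3ccccc3O)n2)c1`, compound 2 `Oc1ccc(-c2cc(-c3ccsc3)cc(-c3ccccc3O)n2)cc1` and compound 3 `Oc1ccc(-c2cc(-c3ccsc3)cc(-c3cccc(O)c3)n2)cc1`. In an assay on isolated protein for inhibition of DNA topoisomerase 1 (Homo sapiens), with a stated time of 30 min, tested at 100 uM (a lower number here means a weaker effect, a higher number a stronger effect of the compound at the concentration tested), compound 1 gives 10.2%, compound 2 gives 13.8% and compound 3 gives 17.1%. Compound 2 stands second highest of these three numbers, and its gaps to compound 3 and to compound 1 both lie within the scatter, as the steps of a number 3.6 percentage points higher from compound 1 to compound 2 (within the scatter), a number 3.3 percentage points higher from compound 2 to compound 3 (within the scatter) and a number 6.9 percentage points higher from compound 1 to compound 3 (within the scatter) show. Compound 4 `Oc1ccc(-c2cc(-c3cccnc3)cc(-c3ccccc3O)n2)cc1` differs from compound 2 by pyridin-3-yl in place of thiophen-3-yl on an aromatic carbon. Going by the values given here, no measured step involves this kind of exchange; the measured steps all swap hydroxyphenyl groups, and none reaches beyond the scatter. Therefore no step beyond the scatter is expected in this assay, and a number 0.8 percentage points lower from compound 2 to compound 4 (within the scatter) is the expected step. Compound 4 is estimated at 13%, within the range 3% to 25%.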

Compound 4, a percentage reported as inhibition, at one concentration (the size of the read-out at that concentration, not a potency): 1.5%
For compound 4 the middle estimate is 11.5 percentage points above the measured one, outside the stated range (below it).
By their numbers in this assay, from the lowest: compounds 4, 1, 2 and 3 (each within the scatter of the next, the first and the last beyond it).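

In this assay, going by these compounds alone, the exchange of thiophen-3-yl for pyridin-3-yl, opposite the ring nitrogen, gives a number 12.3 percentage points lower from compound 2 to compound 4 (beyond the scatter) and so is the first change to go beyond the scatter. The swaps of hydroxyphenyl groups among compound 1, compound 2 and compound 3 had all stayed within it, so this position responds to a change where those did not. Nothing available explains this step.

Going by these compounds, what a plain phenyl or a furan-3-yl would give at this position stays open, as does whether the same exchange would carry over to compound 1 or compound 3.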